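The compounds below may be only part of what the source reports. "The series", "measured", "known", "first", "only" and "open" are said of these compounds alone.

Measured so far:
- compound 1 `CC(C)C(C(=O)NC(N)=O)C(C)C`, which in a functional assay on the whole organism (strain Sprague-Dawley) with Rattus norvegicus as the target (a lower number here means that less compound is needed, a higher number that more compound is needed for the effect), gives 16 mg/kg
- compound 2 `CCCC(C(N)=O)C(C)C`, which in this assay gives 27 mg/kg

Compound 2 has the higher of the two doses in this assay, but the gap to compound 1 lies within the scatter, so the two cannot be told apart on these numbers. Among the measured compounds shown here, the two structures differ in more than one place, so no single step links them.

The next compound, compound 3 `CC(C)C(C(N)=O)C(C)C`, is a rearrangement of compound 2 with the same atoms joined differently: isopropyl in place of propyl on a saturated chain carbon bound to a carbonyl carbon and a saturated chain carbon. Branching of this kind is the only change, and no measured pair shows what such a change does in this assay. The same branched carbon skeleton as in compound 3 is carried by compound 1, which gives 16 mg/kg in this assay, and this hints that this skeleton is at least tolerated. Compound 3 is therefore expected to show a step of a 1.4-fold lower number from compound 2 to compound 3 (0.13 log units; within the scatter), a small shift toward a lower dose that may not exceed the scatter. The expected value for compound 3 in this assay is 20 mg/kg, within a range from 9 mg/kg to 45 mg/kg.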

Compound 3, dose for half-maximal effect: 60 mg/kg
For compound 3 the middle estimate is 3.0-fold (0.48 log units) below the measured one; measured number above the stated range.
By their numbers in this assay, from the lowest: compounds 1 and 2 (each within the scatter of the next); then compound 3.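

In this assay the change from propyl to isopropyl on a saturated chain carbon bound to a carbonyl carbon and a saturated chain carbon is not neutral: it gives a 2.2-fold higher number from compound 2 to compound 3 (0.35 log units; beyond the scatter) and so more compound is needed for the effect. The branched skeleton alone therefore does not bring the lower dose seen for compound 1, since hydrogen in place of carbamoyl on an amide-type nitrogen gives a 3.8-fold higher number from compound 1 to compound 3 (0.57 log units; beyond the scatter) on that same skeleton. Both changes matter in this small set, but the data do not explain why, as no supporting measurement bears on either step.

The compounds shown leave open whether a longer chain such as butyl, or a ring such as cyclopropyl, in place of propyl would behave like propyl or like isopropyl. They also leave open whether an acetyl group could stand in for carbamoyl on the amide-type nitrogen, and what carbamoyl on that nitrogen would do when the chain is propyl, as in compound 2.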